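The source may hold more compounds than are shown below. What is called first, only, known or untested is meant among the compounds shown, and "the series" means these compounds.

Compound 2 `Cc1ccc(CNC(=O)C(CC(C)O)N(C)CCC=C(c2sccc2C)c2sccc2C)cc1` stands highest of the three measured compounds in a physicochemical assay for lipophilicity, read by HPLC (a higher number here means a more lipophilic compound, a lower number a more polar compound), giving 6.15. Its nearest neighbour in this assay is compound 1 `Cc1ccsc1C(=CCCN(C)C(CCO)C(=O)NCc1ccccc1)c1sccc1C`, which gives 5.71; furthest from it is compound 3 `Cc1ccsc1C(=CCCN(C)C(CC(C)O)C(=O)NCc1ccc(F)cc1)c1sccc1C`, which gives 5.51. Among the measured compounds shown here, the only single-site step among the measured compounds is the one in which fluoro replaces methyl on an aromatic carbon, and it reads a number 0.64 log units lower from compound 2 to compound 3 (beyond the scatter).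

Compound 4 `Cc1ccc(CNC(=O)C(CCO)N(C)CCC=C(c2sccc2C)c2sccc2C)cc1` is not yet measured in this assay. It differs from compound 2 in one place: hydrogen in place of methyl on a saturated chain carbon bound to an oxygen on a saturated carbon and a saturated chain carbon. For the measured compounds named here, no measured pair isolates this change. Compound 1 and compound 2 differ both at the chain and on the aromatic ring, so the gap between them spans two changes at once and cannot be split between them: compound 1 gives 5.71, and compound 2 gives 6.15. What the numbers do show is that removing one carbon from a compound of this series has so far gone with a lower reading, not a higher one. Compound 4 is therefore expected to lie a little below compound 2, with an estimated step of a number 0.35 log units lower from compound 2 to compound 4 (beyond the scatter). For compound 4 the estimate in this assay is 5.8, with a range from 5.4 to 6.2.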

Compound 4, partition coefficient: 6.2
The estimate for compound 4 lay 0.40 log units below the measured number; the range from low to high includes it.
By their numbers in this assay, from the lowest: compounds 3 and 1 (each within the scatter of the next); then compounds 2 and 4 (each within the scatter of the next).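

In this assay, among the compounds shown here, this is the first pair that isolates the chain position, and going from 2-hydroxypropyl to 2-hydroxyethyl leaves the reading within the scatter (a number 0.05 log units higher from compound 2 to compound 4 (within the scatter)), so the methyl on this saturated chain carbon makes no readable difference in this pair. The same result supplies a clean step at the aromatic carbon, where methyl in place of hydrogen gives a change beyond the scatter (a number 0.49 log units higher from compound 1 to compound 4 (beyond the scatter)); among the single-site steps now available, the two at the aromatic carbon read beyond the scatter and the one at the chain does not, and compound 4 goes against the earlier impression that removing a carbon goes with a lower reading. Nothing in the information available explains why the chain methyl and the aromatic methyl differ in this way.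

From the compounds shown here alone, whether the chain position would stay as flat with a larger change, such as an ethyl or a longer chain on that carbon, or an amine in place of the hydroxyl, remains open, since it rests on a single pair. Going by these compounds, it is also open how the aromatic carbon would read with chloro or methoxy, and whether the steps seen there hold on other versions of the chain.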